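Swapping imidazole for furan on a weak compound

The source may hold more compounds than are shown below. What is called first, only, known or untested is meant among the compounds shown, and "the series" means these compounds.

Measured in a functional assay on A-375 cells (Homo sapiens) for antiproliferative activity; a lower number here means a stronger inhibitor, a higher number a weaker inhibitor
Compound 1 `O=C(Nc1ccc(-c2cccnc2)cc1)C1CCCN(Cc2ccc(F)c(F)c2)C1` gives 610 nM
Compound 2 `O=C(Nc1ccc(-c2c[nH]cn2)cc1)C1CCCN(Cc2ccc(F)c(F)c2)C1` gives > 20000 nM (a limit)

Compound 2 has no exact number, only a limit, > 20000 nM. This is the weak end of the two results so far. Compound 3 `O=C(Nc1ccc(-c2ccco2)cc1)C1CCCN(Cc2ccc(F)c(F)c2)C1` keeps the rest of the molecule and changes one ring: furan-2-yl in place of 1H-imidazol-4-yl on an aromatic carbon. Here furan-2-yl takes the place of 1H-imidazol-4-yl on an aromatic carbon, para to a large group.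

Among the compounds with values here, only one measured step bears on this site. It is an at least 32-fold higher number from compound 1 to compound 2 (1.51 log units; beyond the scatter), a large change beyond the scatter, and it came with the arrival of 1H-imidazol-4-yl in place of pyridin-3-yl. Compound 3 removes that same group, so a large move toward a lower number, meaning a stronger inhibitor, seems likely. Furan-2-yl itself has not been tested, however, so a full return to the level of compound 1 at 610 nM is not assumed.

The expected change in this assay is an at least 11-fold lower number from compound 2 to compound 3 (1.04 log units; beyond the scatter). For compound 3 the estimate is 1800 nM, with an expected range of 450 nM to 9000 nM.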

Compound 3, half-maximal inhibitory concentration: 1040 nM
Compound 3: the middle estimate sits 1.7-fold (0.24 log units) above what was measured, within the range that was stated.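

In this assay, furan-2-yl in place of 1H-imidazol-4-yl gives an at least 19-fold lower number from compound 2 to compound 3 (1.28 log units; beyond the scatter), so the loss seen with 1H-imidazol-4-yl does not extend to every five-membered aromatic ring at this position. Set against pyridin-3-yl, furan-2-yl gives a 1.7-fold higher number from compound 1 to compound 3 (0.23 log units; within the scatter), which means that these two rings cannot be told apart in this assay and that a five-membered ring is not in itself an obstacle here. Compound 2 carries only a limit, so the full size of its step to compound 3 stays unknown: the limit of > 20000 nM in this assay, at which 1 of the 3 values shown sits.

What sets 1H-imidazol-4-yl apart remains open: compared with furan-2-yl it has two nitrogen atoms in place of one oxygen and adds a hydrogen-bond donor, and these differences cannot be separated with the compounds shown. A thiophene ring, a plain phenyl ring or an imidazole carrying a methyl group on its nitrogen would help to show which of these differences matters at this position.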